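Compound 3 to compound 4: trifluoromethoxy for trifluoromethyl

The source may hold more compounds than are shown below. What is called first, only, known or untested is meant among the compounds shown, and "the series" means these compounds.

Measured values (an ADME assay on microsomes from liver (Rattus norvegicus) for metabolic stability, with a stated time of 10 min; a lower number here means that less of the compound is left, a higher number that more of the compound is left)
- compound 1 `FC(F)(F)c1ccccc1-c1ccc2[nH]c(C3=NC4(CCCCC4)CO3)nc2c1` gives 38%
- compound 2 `FC(F)(F)c1ccccc1-c1ccc2[nH]c(C3=NCC4(CCCCC4)N3)nc2c1` gives 91%
- compound 3 `FC(F)(F)c1ccccc1-c1ccc2[nH]c(C3=NOC4(CCCCC4)C3)nc2c1` gives 75%

Compound 3 stands second highest of the three, lower than compound 2 and higher than compound 1, with both gaps beyond the scatter. Compound 4 `FC(F)(F)Oc1ccccc1-c1ccc2[nH]c(C3=NOC4(CCCCC4)C3)nc2c1` carries trifluoromethoxy in place of trifluoromethyl on an aromatic carbon. Among the measured compounds shown here, no measured pair shows this change, so the only anchor is compound 3 at 75% and the uncertainty is wide. The expected step in this assay is small and downward, within the scatter (a number 7 percentage points lower from compound 3 to compound 4 (within the scatter)). Compound 4 is estimated at 68% (expected range 48% to 86%).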

Compound 4, percent of the compound remaining: 74%
Estimate against measurement, compound 4: 6 percentage points below; the range from low to high includes it.
By their numbers in this assay, from the lowest: compound 1; then compounds 4 and 3 (each within the scatter of the next); then compound 2.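

In this assay, trifluoromethoxy in place of trifluoromethyl on an aromatic carbon, ortho to a large group, gives a number 1 percentage points lower from compound 3 to compound 4 (within the scatter). Among the compounds shown here, compound 1, compound 2 and compound 3 all hold trifluoromethyl here, so this pair is the only reading of the position, and on this core the swap leaves the read-out within the scatter. No measurement bears on why this result occurs. From the compounds shown here alone, what an amine or a carboxylic acid on this aromatic carbon would give remains open. Going by these compounds, whether the swap reads the same on the cores of compound 1 and compound 2 also remains open.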